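The source may report more compounds than this note shows. Statements on the series, on what has been measured and on what is new or still open speak of the compounds shown alone.

In an assay on lysate for inhibition of 6-phosphofructo-2-kinase/fructose-2,6-bisphosphatase 3 (Homo sapiens), with stated times of 0.5 min and 45 min (on this read-out higher numbers stand for weaker inhibition and lower numbers for stronger inhibition), compound 3 `CN1CCCC(NS(=O)(=O)c2ccccc2Nc2cc(-c3ccc4ccn(C)c4c3)c3nccnc3c2)C1` gives 9780 nM, the highest of the two numbers shown; the nearest is compound 2 `Cn1ccc2ccc(-c3cc(Nc4ccccc4S(=O)(=O)N4CCOCC4)cc4nccnc34)cc21` at 2640 nM, a step of a 3.7-fold higher number from compound 2 to compound 3 (0.57 log units; beyond the scatter). Compound 1 `Cn1ccc2ccc(-c3cc(Nc4ccccc4S(=O)(=O)Nc4cncnc4)cc4nccnc34)cc21` sits at a limit of this assay, > 100000 nM. That is the limit of > 100000 nM in this assay, at which 1 of the 3 values shown sits. The step to compound 4 `Cn1cc(CNS(=O)(=O)c2ccccc2Nc2cc(-c3ccc4ccn(C)c4c3)c3nccnc3c2)cn1` is (1-methyl-1H-pyrazol-4-yl)methyl in place of 1-methylpiperidin-3-yl on a sulfonamide nitrogen. The measured steps bearing on this position are an at least 10-fold lower number from compound 1 to compound 3 (1.00 log units; beyond the scatter) and an at least 37-fold lower number from compound 1 to compound 2 (1.57 log units; beyond the scatter), both large, and both showing the aromatic pyrimidin-5-yl group at the weak end. Compound 4 brings back an aromatic ring on the sulfonamide nitrogen, so a modest move toward weaker inhibition is expected, a 1.6-fold higher number from compound 3 to compound 4 (0.21 log units; within the scatter). Compound 4 is therefore estimated at 16000 nM, ranging from 4000 nM to 64000 nM.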

Compound 4, half-maximal inhibitory concentration: > 100000 nM
Compound 4: only a limit was reported (the forecaster's own chance of this, stated with the estimate: 15%); at least 6.2-fold (0.79 log units) between middle value and limit.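

Putting the aromatic (1-methyl-1H-pyrazol-4-yl)methyl group on the sulfonamide nitrogen gives an at least 10-fold higher number from compound 3 to compound 4 (1.00 log units; beyond the scatter), and an at least 37-fold higher number from compound 2 to compound 4 (1.57 log units; beyond the scatter). The weak end at this position therefore holds a second aromatic ring, one set on a methyl link rather than directly on the nitrogen, and no compound shown goes against this. The value of compound 4 is a limit, as is that of compound 1, so the step between them cannot be read: the limit of > 100000 nM in this assay, at which 2 of the 4 values shown sit.

Whether the aromatic ring itself accounts for the loss stays open. A benzyl or cyclohexylmethyl group on the sulfonamide nitrogen would bear on that.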